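Amide nitrogen substituents in a growth-inhibition series

The source may report more compounds than this note shows. Statements on the series, on what has been measured and on what is new or still open speak of the compounds shown alone.

In a functional assay on PC-3 cells (Homo sapiens) for inhibition, read by MTT assay (a lower number here means a stronger inhibitor of growth, a higher number a weaker inhibitor of growth), compound 1 `CC1=C(/C=C/C(C)=C/C=C/C(C)=C\C(=O)Nc2cccc(F)c2)C(C)(C)CCC1n1ccnc1` gives 5620 nM, and compound 2 `CC1=C(/C=C/C(C)=C/C=C/C(C)=C\C(=O)Nc2ccc(F)cc2)C(C)(C)CCC1n1ccnc1` gives 30200 nM, the higher of the two numbers and so the weaker growth inhibition. Compound 3 `CC1=C(/C=C/C(C)=C/C=C/C(C)=C\C(=O)NCc2ccc(O)cc2)C(C)(C)CCC1n1ccnc1` has 4-hydroxybenzyl in place of 4-fluorophenyl on an amide-type nitrogen, with the shared core unchanged: 4-hydroxybenzyl in place of 4-fluorophenyl on an amide-type nitrogen. Within the data shown here, the only measured step, 4-fluorophenyl in place of 3-fluorophenyl, is a 5.4-fold higher number from compound 1 to compound 2 (0.73 log units; beyond the scatter); it is modest but beyond the scatter. Among the measured compounds shown here, it shows that a change at this nitrogen can move the number, yet no measured step covers a 4-hydroxybenzyl group, so it serves only as a rough guide to size. A modest move towards a lower number is expected, with wide uncertainty, and the expected step is a 4.3-fold lower number from compound 2 to compound 3 (0.63 log units; beyond the scatter). For compound 3 the estimate is 7000 nM, with an expected range of 1500 nM to 30000 nM.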

Compound 3, concentration for 50% growth inhibition: 3540 nM
Compound 3: the middle estimate sits 2.0-fold (0.30 log units) above what was measured; the measured number falls inside the stated range.
By their numbers in this assay, from the lowest: compounds 3 and 1 (each within the scatter of the next); then compound 2.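

In this assay, the step from 4-fluorophenyl to 4-hydroxybenzyl on the amide-type nitrogen is an 8.5-fold lower number from compound 2 to compound 3 (0.93 log units; beyond the scatter) and lies beyond the scatter, so a benzyl group carrying a hydroxyl is compatible with a number in the range of compound 1. The comparison with 3-fluorophenyl is a 1.6-fold lower number from compound 1 to compound 3 (0.20 log units; within the scatter) and lies within the scatter, which leaves compound 1 and compound 3 indistinguishable here and compound 2 alone apart from both. No available evidence bears on the reason for either step. The change from compound 2 to compound 3 replaces the fluorine with a hydroxyl and adds a carbon on the nitrogen in one move, so the data cannot assign the step to either part. A 4-fluorobenzyl or 4-hydroxyphenyl group on this nitrogen would separate the two, and a 2-phenylethyl chain would test a longer link.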